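Cyano for Bromo on the Benzyl Group of Compound 1

The source may hold more compounds than are shown below. What is called first, only, known or untested is meant among the compounds shown, and "the series" means these compounds.

Compound 1, `O=c1ccoc2cc(OCc3cn(Cc4cccc(Br)c4)nn3)ccc12`: in a functional assay on HeLa cells (Homo sapiens) for cytotoxicity, read by MTT assay, with a stated time of 48 h (a higher number here means a weaker inhibitor, a lower number a stronger inhibitor), compound 1 gives > 100000 nM, which is a limit of the assay and not a number.
Compound 2, `Cc1ccccc1Cn1cc(COc2ccc3c(=O)ccoc3c2)nn1`: compound 2 gives 15300 nM.
Compound 3, `O=c1ccoc2cc(OCc3cn(Cc4ccc(Br)cc4)nn3)ccc12`: compound 3 gives > 100000 nM, again a limit of the assay.

Compound 1 thus stands at the limit of > 100000 nM in this assay, at which 2 of the 3 values shown sit. Compound 4, `N#Cc1cccc(Cn2cc(COc3ccc4c(=O)ccoc4c3)nn2)c1`, differs from it by cyano in place of bromo on an aromatic carbon. For the measured compounds named here, no measured step tests cyano against bromo. The nearest steps are an at least 6.5-fold lower number from compound 1 to compound 2 (0.81 log units; beyond the scatter), a step that the two limits leave unreadable from compound 1 to compound 3 and an at least 6.5-fold higher number from compound 2 to compound 3 (0.81 log units; beyond the scatter). They show that changing the group on the benzyl ring can move the number at least modestly, but they give no direction for cyano. The step is therefore expected to be an at least 1.6-fold lower number from compound 1 to compound 4 (0.22 log units; that floor lies within the scatter), with a fair chance of another limit. Compound 4 is estimated at 60000 nM, within a range from 10000 nM to 200000 nM.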

Compound 4, half-maximal inhibitory concentration: > 100000 nM
Compound 4 was reported as a limit (the forecaster's own chance of this, stated with the estimate: 50%); at least 1.6-fold (0.22 log units) between middle value and limit.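

Putting cyano in place of bromo leaves compound 4 at a limit of the assay rather than at a measured number, so a third compound now sits there: the limit of > 100000 nM in this assay, at which 3 of the 4 values shown sit. The steps from compound 1 and from compound 3 to compound 4 therefore cannot be read. The one readable step is an at least 6.5-fold higher number from compound 2 to compound 4 (0.81 log units; beyond the scatter), so among the groups shown, only 2-methylphenyl gives a measured number.

From the compounds shown here alone, how far compound 1, compound 3 and compound 4 truly differ stays unknown. Also open, going by these compounds, is whether an amine or a carboxylic acid in place of bromo would give a measured number.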